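The source may hold more compounds than are shown below. What is called first, only, known or untested is meant among the compounds shown, and "the series" means these compounds.

In a physicochemical assay, with a stated time of 6 min (a lower number here means a stronger inhibitor, a higher number a weaker inhibitor), compound 1 (`COc1ccc(NC(=O)Nc2nc(-c3cc4cc(Br)ccc4o3)cs2)cc1`) gives > 200000 nM, a limit of the assay and not a number. Among the compounds with values here, compound 2 (`O=C(Nc1nc(-c2cc3cc(Br)ccc3o2)cs1)Nc1ccccc1[N+](=O)[O-]`) gives 166000 nM, the only actual number so far. Compound 3 (`COc1cccc(NC(=O)Nc2nc(-c3cc4cc(Br)ccc4o3)cs2)c1`) differs from compound 2 by 3-methoxyphenyl in place of 2-nitrophenyl on an amide-type nitrogen. Within the data shown here, one measured step bears on this change, the swap of 4-methoxyphenyl for 2-nitrophenyl at that same place: an at least 1.2-fold lower number from compound 1 to compound 2 (0.08 log units; that floor lies within the scatter). That step gives only a floor, and its full size is not known. The closest reference for a methoxyphenyl is compound 1 at > 200000 nM, again a limit. No change beyond the scatter is therefore expected in this assay, and a reading at the limit is quite possible. The expected step is a 1.1-fold higher number from compound 2 to compound 3 (0.04 log units; within the scatter). Compound 3 is estimated at 180000 nM, with an expected range of 80000 nM to 350000 nM.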

Compound 3, half-maximal inhibitory concentration: > 200000 nM
Compound 3 was reported as a limit (the forecaster's own chance of this, stated with the estimate: 50%); at least 1.1-fold (0.04 log units) between middle value and limit.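

In this assay, 3-methoxyphenyl in place of 2-nitrophenyl on the amide-type nitrogen gives an at least 1.2-fold higher number from compound 2 to compound 3 (0.08 log units; that floor lies within the scatter), so this change shows no movement beyond the scatter, and the size given is only a floor. Compound 3 gives > 200000 nM, a limit of the assay and not a number, so a second methoxyphenyl compound joins compound 1 without a readable value, and the step between those two cannot be read. Compound 2 remains the only compound with an actual number, and this position has so far yielded readings only at the edge of the range: the limit of > 200000 nM in this assay, at which 2 of the 3 values shown sit.

Going by these compounds, whether an amine or a carboxylic acid at this place would give a number clearly away from that limit stays open. How far compound 1 and compound 3 lie past the limit is also unknown, so no order among the three compounds can be given.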